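Side-chain swap on an amide-bearing vitamin D receptor ligand

A few compounds are considered here, and "the series" means these few. Any claim that something is new, unique, unknown or untested is made for them only; others in the source may bear on it.

Compound 1 `CCn1c(C(=O)NCCN)ccc1C(CC)(CC)c1ccc(OCC(=O)C(C)(C)C)c(C)c1`: 120 nM
Compound 2 `CCn1c(C(=O)N(C)CCC#N)ccc1C(CC)(CC)c1ccc(OCC(=O)C(C)(C)C)c(C)c1`: 9800 nM
Compound 3 `CCn1c(C(=O)NCCN)ccc1C(CC)(CC)c1ccc(OCC(O)C(C)(C)C)c(C)c1`: 10 nM

All three were measured in an assay on HL-60 cells for agonist activity at vitamin D3 receptor (Homo sapiens), read by microscopy, with a stated time of 96 h; on this read-out lower numbers stand for an effect already at smaller amounts and higher numbers for an effect only at larger amounts of compound. Compound 2 differs from compound 1 by (2-cyanoethyl)(methyl)amino in place of (2-aminoethyl)amino on a carbonyl carbon, and this gave an 82-fold higher number from compound 1 to compound 2 (1.91 log units; beyond the scatter). Compound 3 differs from compound 1 in its core by 1-hydroxy-2,2-dimethylpropyl in place of (tert-butyl)carbonyl on a saturated chain carbon bound to an oxygen on an aromatic ring, which gave a 12-fold lower number from compound 1 to compound 3 (1.08 log units; beyond the scatter). Compound 4 `CCn1c(C(=O)N(C)CCC#N)ccc1C(CC)(CC)c1ccc(OCC(O)C(C)(C)C)c(C)c1` has not yet been measured. It differs from compound 3 by (2-cyanoethyl)(methyl)amino in place of (2-aminoethyl)amino on a carbonyl carbon, the same change as between compound 1 and compound 2, made at the same place on a different core. The expected step is an 80-fold higher number from compound 3 to compound 4 (1.90 log units; beyond the scatter), because the same change gave an 82-fold higher number from compound 1 to compound 2 (1.91 log units; beyond the scatter) in this assay. Compound 4 is estimated at 800 nM, with a likely range from 250 nM to 2500 nM.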

Compound 4, half-maximal effective concentration: 1960 nM
The estimate for compound 4 lay 2.5-fold (0.39 log units) below the measured number; the measured number falls inside the stated range.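

The (2-cyanoethyl)(methyl)amino change carried over to the core of compound 3, with a 200-fold higher number from compound 3 to compound 4 (2.29 log units; beyond the scatter) in this assay: the same change on two cores in this assay, an 82-fold higher number (1.91 log units; beyond the scatter) from compound 1 to compound 2 and a 200-fold higher number (2.29 log units; beyond the scatter) from compound 3 to compound 4, 2.4-fold (0.38 log units) apart, within the scatter of two such steps. The change to 1-hydroxy-2,2-dimethylpropyl from (tert-butyl)carbonyl also carried over, with a 5.0-fold lower number from compound 2 to compound 4 (0.70 log units; beyond the scatter): the same change on two cores in this assay, a 12-fold lower number (1.08 log units; beyond the scatter) from compound 1 to compound 3 and a 5.0-fold lower number (0.70 log units; beyond the scatter) from compound 2 to compound 4, 2.4-fold (0.38 log units) apart, within the scatter of two such steps. Among these compounds, this rests on only two cores in one assay, so it does not show that either step would hold on any other core.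

The change replaces an amine with a nitrile and adds a methyl in one move, and the compounds shown leave open which of the two sets the size of the step. On these data alone, how a longer amine chain on the same carbonyl carbon would read also remains open.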